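A few compounds are considered here, and "the series" means these few. Any claim that something is new, unique, unknown or untested is made for them only; others in the source may bear on it.

Compound 1 `CCCCNC(=O)c1ccc2c(ccn2-c2ncc3c(n2)N(C2CCCC2)[C@H](CC)C(=O)N3C)c1` was tested in a functional assay on NCI-H1975 cells (Homo sapiens) for antiproliferative activity, read by CCK-8 assay, with a stated time of 72 h (a lower number here means a stronger inhibitor of growth, a higher number a weaker inhibitor of growth), where compound 1 gives 990 nM, the lowest of the three numbers shown. Compound 2 `CC[C@@H]1C(=O)N(C)c2cnc(Nc3ccc(S(=O)(=O)NCCCO)cc3)nc2N1C1CCCC1` gives 2140 nM in this assay, and compound 3 `CCCNC(=O)c1ccc2c(ccn2-c2ncc3c(n2)N(c2ccn(C)n2)C(CC)C(=O)N3C)c1` gives 11000 nM; both gaps from compound 1 lie beyond the usual scatter of such measurements. Compound 4 `CC[C@@H]1C(=O)N(C)c2cnc(-n3ccc4ccccc43)nc2N1C1CCCC1` has not been measured, and it differs from compound 1 as follows: hydrogen in place of butylcarbamoyl on an aromatic carbon The departing group sits on an aromatic carbon of a six-membered aromatic ring of carbon only, within a fused system of two rings. Among the compounds with values here, no measured pair shows a comparable step, so the direction rests on expectation alone. Compound 4 is expected to inhibit growth less strongly than compound 1, with an estimate of 3500 nM, between 1000 nM and 12000 nM. The expected step is a 3.5-fold higher number from compound 1 to compound 4 (0.55 log units; beyond the scatter).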

Compound 4, concentration for 50% growth inhibition: 28300 nM
Compound 4: the middle estimate sits 8.1-fold (0.91 log units) below what was measured; the whole stated range lies below it.
By their numbers in this assay, from the lowest: compound 1; then compound 2; then compound 3; then compound 4.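

In this assay, replacing butylcarbamoyl with hydrogen on the aromatic carbon gives a 29-fold higher number from compound 1 to compound 4 (1.46 log units; beyond the scatter), a large step and the first shown at this position. Growth inhibition by compound 1 therefore depends heavily on what this carbon carries. Nothing available explains the size of this step. The compounds shown leave open which part of butylcarbamoyl counts: the carbonyl, the amide hydrogen or the butyl chain. They also do not show how a carboxylic acid, an amine or a longer chain would fare on this carbon.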